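Iodo removal in the series of two measured compounds

The compounds below may be only part of what the source reports. "The series", "measured", "known", "first", "only" and "open" are said of these compounds alone.

Measured compounds:
compound 1 `Oc1nc(NCC2CCCCC2)nc2ccc(I)cc12` — 97.9%
compound 2 `Oc1nc(NCc2ccccc2)nc2ccc(I)cc12` — 106%

In a functional assay on the whole organism (uterus) with Rattus norvegicus as the target, tested at 50 uM (on this read-out lower numbers stand for a stronger effect and higher numbers for a weaker effect at the one concentration tested), compound 1 gives 97.9% and compound 2 gives 106%. Compound 2 has the highest of the two numbers, its nearest neighbour being compound 1, a gap within the scatter, so no order between them can be read. Among the compounds with values here, the single measured step, a number 8.1 percentage points higher from compound 1 to compound 2 (within the scatter), concerns phenyl in place of cyclohexyl and does not touch the aromatic carbon of the fused ring.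

Compound 3 `Oc1nc(NCc2ccccc2)nc2ccccc12` differs from compound 2 by hydrogen in place of iodo on an aromatic carbon. Within the data shown here, no measured step bears on this change, and the two numbers so far sit close together. Compound 3 is therefore expected to show a step of a number 4 percentage points lower from compound 2 to compound 3 (within the scatter) in this assay, none beyond the scatter. The estimate for compound 3 is 102%, expected to lie between 85% and 116%.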

Compound 3, a percentage reported as activity, at one concentration (the size of the read-out at that concentration, not a potency): 47.4%
The estimate for compound 3 lay 54.6 percentage points above the measured number, outside the stated range (below it).
By their numbers in this assay, from the lowest: compound 3; then compounds 1 and 2 (each within the scatter of the next).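

In this assay, within the data shown here, hydrogen in place of iodo on the aromatic carbon gives a number 58.6 percentage points lower from compound 2 to compound 3 (beyond the scatter), the first step beyond the scatter. This aromatic carbon therefore matters for the read-out in a way the phenyl for cyclohexyl change could not show, as that change gives a number 8.1 percentage points higher from compound 1 to compound 2 (within the scatter) and stays within the scatter. Since a lower number stands for a stronger effect at the one concentration tested, the compound without iodo is the stronger of this pair, although nothing shown accounts for the size of the step.

The compounds shown leave open whether the step is specific to iodo or would also appear with chloro, fluoro or methoxy on this aromatic carbon. They also leave open whether removing iodo gives a step of similar size when cyclohexyl replaces phenyl on the chain.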